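Methyl to Methoxy Swap on Two Related Cores

The source may hold more compounds than are shown below. What is called first, only, known or untested is meant among the compounds shown, and "the series" means these compounds.

Measured compounds and values:
compound 1, `Cc1ccc(-n2cc(NC(=O)c3cccc(NS(=O)(=O)c4ccc(Cl)cc4)c3)cn2)cc1`, gives 2440 nM in a functional assay on HepG2 cells (Homo sapiens) for inhibition, read by MTT assay, with a stated time of 48 h; on this read-out lower numbers stand for stronger inhibition and higher numbers for weaker inhibition
compound 2, `COc1ccc(-n2cc(NC(=O)c3cccc(NS(=O)(=O)c4ccc(Cl)cc4)c3)cn2)cc1`, gives 15200 nM in this assay
compound 3, `Cc1ccc(-n2cc(NC(=O)c3ccc(NS(=O)(=O)c4ccc(Cl)cc4)cc3)cn2)cc1`, gives 9720 nM in this assay

Compound 1 and compound 2 share a core and differ only in one place: methoxy in place of methyl on an aromatic carbon. That change gives a 6.2-fold higher number from compound 1 to compound 2 (0.79 log units; beyond the scatter), a loss of inhibition that lies beyond the scatter.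

Compound 3 carries the same atoms as compound 1, joined differently; the difference between the two cores is not broken down here. Compound 3 stands at the weaker end of the three measured values: its number is within the scatter of compound 2, and beyond the scatter from compound 1.

Compound 4, `COc1ccc(-n2cc(NC(=O)c3ccc(NS(=O)(=O)c4ccc(Cl)cc4)cc3)cn2)cc1`, is not yet measured. It relates to compound 3 as compound 2 relates to compound 1: methoxy in place of methyl on an aromatic carbon. The place lines of both changes read the same word for word, so this is the same change made on the core of compound 3.

The expectation for compound 4 rests on a single prior example of this change. For the measured compounds named here, compound 4 is expected to lose inhibition against compound 3 by about a 4.1-fold higher number from compound 3 to compound 4 (0.61 log units; beyond the scatter), a step taken from the measured pair because a 6.2-fold higher number from compound 1 to compound 2 (0.79 log units; beyond the scatter) is the only guide available, with the step size softened since one example on a different core may not carry over in full. Compound 4 is therefore estimated at 40000 nM in this assay, with a range from 14000 nM to 110000 nM. A number this weak may come back only as a limit of the assay rather than a measured value.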

Compound 4, half-maximal inhibitory concentration: 19100 nM
The estimate for compound 4 lay 2.1-fold (0.32 log units) above the measured number; measured number inside the range.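

In this assay, the change from 4-methylphenyl to 4-methoxyphenyl on the core of compound 3 gives a 2.0-fold higher number from compound 3 to compound 4 (0.29 log units; within the scatter), so on this core the two compounds cannot be told apart, whereas on the core of compound 1 the same change gave a 6.2-fold higher number from compound 1 to compound 2 (0.79 log units; beyond the scatter). The size of the step therefore did not carry over intact from one core to the other, and the gap between the two steps is itself larger than repeat scatter would explain: the same change on two cores in this assay, a 6.2-fold higher number (0.79 log units; beyond the scatter) from compound 1 to compound 2 and a 2.0-fold higher number (0.29 log units; within the scatter) from compound 3 to compound 4, 3.2-fold (0.50 log units) apart, beyond the scatter of two such steps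

These two pairs show only that the outcome of this change depends on the core in this series; they do not show which feature of the cores, which carry the same atoms joined differently, sets the step, nor how the change would behave on a third core.

Still open, on these data alone, is whether other groups at the same place on the ring, such as an amine, a carboxylic acid or a longer chain, would also respond differently on the two cores. Also open, as far as these compounds go, is whether the two cores would part in the same way in any read-out other than this assay.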